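The source may report more compounds than this note shows. Statements on the series, on what has been measured and on what is new or still open speak of the compounds shown alone.

Working notes on the series. Among the measured compounds shown here, compound 1 `CC/C=C\[C@H](C)[C@H](OC(N)=O)[C@@H](C)[C@H](O)[C@@H](C)C/C(C)=C\[C@H](C)[C@@H](O)[C@@H](C)/C=C\[C@@H](O)C[C@@H]1OC(=O)NC[C@H]1C` is the reference point; in a functional assay on A549 cells (Homo sapiens) for antiproliferative activity (on this read-out lower numbers stand for stronger inhibition of growth and higher numbers for weaker inhibition of growth), compound 1 gives 520 nM, the lowest of the two numbers measured so far. For the measured compounds named here, compound 2 `CC/C=C\[C@H](C)[C@H](OC(N)=O)[C@@H](C)[C@H](O)[C@@H](C)C/C(C)=C\[C@H](C)[C@@H](O)[C@@H](C)/C=C\[C@@H](O)C[C@H](O)[C@H](C)C[C@H](C)C(=O)OC` is the one measured comparison: in this assay compound 2 gives 4000 nM, and the step of a 7.7-fold higher number from compound 1 to compound 2 (0.89 log units; beyond the scatter) goes with a group of 11 heavy atoms (8 carbon, 3 oxygen; no ring) in place of a group of 8 heavy atoms (5 carbon, 1 nitrogen, 2 oxygen; one six-membered non-aromatic ring with 2 hetero atoms), on a saturated chain carbon, two bonds along the chain from a double-bonded chain carbon and an oxygen on a saturated carbon.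

Compound 3 `CC/C=C\[C@H](C)[C@H](OC(N)=O)[C@@H](C)[C@H](O)[C@@H](C)C/C(C)=C\[C@H](C)[C@@H](O)[C@@H](C)/C=C\[C@@H](O)C[C@@H]1OC(=O)[C@H](C)C[C@H]1C` differs from compound 1 at the same place: a group of 9 heavy atoms (7 carbon, 2 oxygen; one six-membered non-aromatic ring with 1 hetero atom) in place of a group of 8 heavy atoms (5 carbon, 1 nitrogen, 2 oxygen; one six-membered non-aromatic ring with 2 hetero atoms), on a saturated chain carbon, two bonds along the chain from a double-bonded chain carbon and an oxygen on a saturated carbon. Here the six-membered non-aromatic ring is kept, with 1 hetero atom rather than 2 and 0 hydrogen-bond donors rather than 1. Going by the values given here, the only step that bears on this place is the one from compound 1 to compound 2, where the ring was lost altogether; it was modest. With the ring retained, a smaller step is expected in this assay, possibly in either direction, and the estimated step of a 1.5-fold lower number from compound 1 to compound 3 (0.17 log units; within the scatter) reflects this. For compound 3 the expected value in this assay is 350 nM, with a range of 90 nM to 1400 nM.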

Compound 3, concentration for 50% growth inhibition: 11 nM
Compound 3: the middle estimate sits 32-fold (1.50 log units) above what was measured; measured number outside the range, below it.
By their numbers in this assay, from the lowest: compound 3; then compound 1; then compound 2.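

Keeping the six-membered non-aromatic ring at this place does not keep the step small: in this assay the group with 1 hetero atom gives a 47-fold lower number from compound 1 to compound 3 (1.67 log units; beyond the scatter), a wider step than the loss of the ring gave, a 7.7-fold higher number from compound 1 to compound 2 (0.89 log units; beyond the scatter). Set against the open chain of 8 carbon and 3 oxygen atoms, the same ring gives a 360-fold lower number from compound 2 to compound 3 (2.56 log units; beyond the scatter), so this place moves the number over a wide span in the three compounds, and compound 3 has the lowest number, with its steps to both others beyond the scatter. The result also shows that two rings of the same size at this place are far from interchangeable, since the ring of compound 1, with 2 hetero atoms and 1 hydrogen-bond donor, sits much closer to the open chain than to the ring of compound 3.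

Still open, going by these compounds, is which counted difference carries the step, as the ring nitrogen, the donor count and the third defined stereocentre all change together, and whether a ring with a methyl group on its nitrogen would fall nearer compound 1 or compound 3. Nothing available here explains the size of this step.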